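This account rests on a few compounds, and the source may have more. Where it says the series, first, only, none or still open, it means among the compounds named here.

Measured so far in a functional assay, read by spectrophotometry, with a stated time of 30 min; on this read-out higher numbers stand for an effect only at larger amounts of compound and lower numbers for an effect already at smaller amounts:
compound 1 `COc1cc(C2Oc3cc([C@H]4Oc5cc(O)cc(O)c5C(=O)[C@@H]4O)ccc3OC2COC(=O)c2ccc(OC)c(OC)c2)ccc1O` gives 77000 nM.
compound 2 `COc1cc(C2Oc3cc([C@H]4Oc5cc(O)cc(O)c5C(=O)[C@@H]4O)ccc3OC2COC(=O)c2ccc([N+](=O)[O-])cc2)ccc1O` gives only a limit, > 300000 nM.
compound 3 `COc1cc(C2Oc3cc([C@H]4Oc5cc(O)cc(O)c5C(=O)[C@@H]4O)ccc3OC2COC(=O)c2cc(N)cc([N+](=O)[O-])c2)ccc1O` gives only a limit, > 300000 nM.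

Compound 3 stands at the limit of this assay, as does compound 2; only compound 1 gives a number. The steps of an at least 3.8-fold higher number from compound 1 to compound 2 (0.59 log units; beyond the scatter) and an at least 3.8-fold higher number from compound 1 to compound 3 (0.59 log units; beyond the scatter) therefore read only as lower bounds, and the step that the two limits leave unreadable from compound 2 to compound 3 cannot be read at all (the limit of > 300000 nM in this assay, at which 2 of the 3 values shown sit).

Compound 4 `COc1cc(C2Oc3cc([C@H]4Oc5cc(O)cc(O)c5C(=O)[C@@H]4O)ccc3OC2COC(=O)/C=C/c2ccc(C)cc2)ccc1O` differs from compound 3 by 2-(4-methylphenyl)ethenyl in place of 3-amino-5-nitrophenyl on a carbonyl carbon. The change removes the nitro-bearing ring that compounds 2 and 3 share and brings in an ester side without donors or acceptors, in that respect nearer to compound 1 than to compound 3. Among the compounds with values here, no measured step covers this exchange directly; the steps from compound 1 bear on it only by showing that the 3,4-dimethoxyphenyl ester gives a number where the two nitrophenyl esters give none. The expectation for compound 4 is a return below the limit, a step of an at least 2.0-fold lower number from compound 3 to compound 4 (0.30 log units; that floor lies within the scatter) downward in this assay, its size uncertain since compound 3 itself is only a limit. Compound 4 is estimated at 150000 nM, between 50000 nM and 400000 nM.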

Compound 4, half-maximal effective concentration: 136000 nM
The estimate for compound 4 lay 1.1-fold (0.04 log units) above the measured number; the measured number falls inside the stated range.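

In this assay, both esters without a nitro group give a number, while both nitro-bearing esters do not: an at least 2.2-fold lower number from compound 3 to compound 4 (0.34 log units; beyond the scatter) and an at least 2.2-fold lower number from compound 2 to compound 4 (0.34 log units; beyond the scatter), so 2-(4-methylphenyl)ethenyl on this carbonyl carbon restores a readable value. Against the only earlier numbered ester, the result is a 1.8-fold higher number from compound 1 to compound 4 (0.25 log units; within the scatter), so 2-(4-methylphenyl)ethenyl and 3,4-dimethoxyphenyl cannot be told apart here. The two downward steps remain floors and the step between compound 2 and compound 3 cannot be read, because both nitro-bearing esters sit at a limit: the limit of > 300000 nM in this assay, at which 2 of the 4 values shown sit.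

On these data alone, how a plain 4-methylphenyl on this carbonyl carbon would compare with compound 4 remains open, so the part played by the ethenyl link is unresolved. Also open, as far as these compounds go, is whether an amine, a carboxylic acid or a longer chain at this place would give a lower number.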